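A few compounds are considered here, and "the series" means these few. Any claim that something is new, unique, unknown or untested is made for them only; others in the source may bear on it.

Compound 1 `CCCCCC1(O)C(=O)Nc2ccc(Nc3ccc(C)cc3)cc21` and compound 3 `CCCCCC1(O)C(=O)Nc2ccc(Nc3ccc(Cl)cc3)cc21` share a core that differs in one place: chloro in place of methyl on an aromatic carbon. In a functional assay on NCI-H460 cells (Homo sapiens) for antiproliferative activity, read by MTT assay, with a stated time of 48 h (on this read-out lower numbers stand for stronger inhibition and higher numbers for weaker inhibition), compound 1 gives only a limit, > 100000 nM. Compound 3 gives 40800 nM in this assay. Compound 2 `Cc1ccc(Nc2ccc3c(c2)C(O)(CCC(C)C)C(=O)N3)cc1` is reached from compound 1 by isopropyl in place of propyl on a saturated chain carbon, two bonds along the chain from a saturated ring carbon, and in this assay compound 2 gives 22700 nM. That change made an at least 4.4-fold lower number from compound 1 to compound 2 (0.64 log units; beyond the scatter), a step whose size is bounded rather than known because of the limit of > 100000 nM in this assay, at which 1 of the 3 values shown sits. The change from compound 1 to compound 3 gave an at least 2.4-fold lower number from compound 1 to compound 3 (0.38 log units; beyond the scatter), likewise set against that limit. Compound 2 and compound 3 lie within the scatter of each other, so no order is drawn between them.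

Compound 4 `CC(C)CCC1(O)C(=O)Nc2ccc(Nc3ccc(Cl)cc3)cc21`, not yet measured in this assay, is reached from compound 3 by the same change, (isopropyl in place of propyl on a saturated chain carbon, two bonds along the chain from a saturated ring carbon), made at the same place on the core of compound 3. Going by the values given here, only one measured pair shows this change, so the expectation for compound 4 rests on an at least 4.4-fold lower number from compound 1 to compound 2 (0.64 log units; beyond the scatter) and on compound 3 at 40800 nM. For compound 4 the expected step is a 4.5-fold lower number from compound 3 to compound 4 (0.66 log units; beyond the scatter), taken as no smaller than the earlier one because an at least 4.4-fold lower number from compound 1 to compound 2 (0.64 log units; beyond the scatter) is a lower bound. Compound 4 is estimated at 9000 nM, expected to fall between 3000 nM and 35000 nM.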

Compound 4, half-maximal inhibitory concentration: 25000 nM
Estimate against measurement, compound 4: 2.8-fold (0.44 log units) below; measured number inside the range.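

In this assay, isopropyl in place of propyl gives a 1.6-fold lower number from compound 3 to compound 4 (0.21 log units; within the scatter) on the chloro core, so the step seen on the methyl core does not carry over at the same size: the same change on two cores in this assay, an at least 4.4-fold lower number (0.64 log units; beyond the scatter) from compound 1 to compound 2 and a 1.6-fold lower number (0.21 log units; within the scatter) from compound 3 to compound 4, at least 2.6-fold (0.43 log units) apart, beyond the scatter of two such steps

Read the other way, chloro in place of methyl gives a 1.1-fold higher number from compound 2 to compound 4 (0.04 log units; within the scatter) on the core with the isopropyl-ended chain, and this change does not carry over at one size either: the same change on two cores in this assay, an at least 2.4-fold lower number (0.38 log units; beyond the scatter) from compound 1 to compound 3 and a 1.1-fold higher number (0.04 log units; within the scatter) from compound 2 to compound 4, at least 2.6-fold (0.43 log units) apart, beyond the scatter of two such steps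

Compound 1 stands in both comparisons only through a limit, so the pairs show that the two changes do not simply add up in these four compounds, but they do not show the true size of the gap, nor why it arises: the limit of > 100000 nM in this assay, at which 1 of the 4 values shown sits.

The compounds shown leave open whether isopropyl in place of propyl would give a step beyond the scatter on a core carrying another group on that aromatic carbon, such as fluoro, methoxy or a nitrile. They also leave open how a longer chain such as hexyl, or a chain ending in an amine or a carboxylic acid, would read in this assay.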